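Chloro-to-amino exchange on a fused core and cytotoxicity

The source may hold more compounds than are shown below. What is called first, only, known or untested is meant among the compounds shown, and "the series" means these compounds.

Of the compounds shown here, three of this set have been tested in a functional assay on SK-MEL-5 cells (Homo sapiens) for cytotoxicity, read by sulforhodamine B assay, with a stated time of 48 h; on this read-out lower numbers stand for higher toxicity in this test and higher numbers for lower toxicity in this test. Compound 1 `ClCc1ccccc1Cn1cnc2c(Cl)nc(Cl)nc21` gives 4260 nM in this assay. Compound 2 `ClCc1cccc(Cn2cnc3c(Cl)nc(Cl)nc32)c1` has the same atoms joined differently; the difference between the two cores is not broken down here, and compound 2 gives 5880 nM in this assay, a number within the usual scatter of that of compound 1. Compound 3 `Nc1nc(Cl)c2ncn(Cc3ccccc3CCl)c2n1` gives 75900 nM in this assay. Compound 3 differs from compound 1 by one change, (amino in place of chloro on an aromatic carbon), and this change made an 18-fold higher number from compound 1 to compound 3 (1.25 log units; beyond the scatter).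

Compound 4 `Nc1nc(Cl)c2ncn(Cc3cccc(CCl)c3)c2n1` has not yet been measured. It differs from compound 2 by the same change, (amino in place of chloro on an aromatic carbon), made on the same kind of position of the core. Among the measured compounds shown here, because the single earlier instance of this change gave an 18-fold higher number from compound 1 to compound 3 (1.25 log units; beyond the scatter), the step from compound 2 to compound 4 in this assay is expected to be a 17-fold higher number from compound 2 to compound 4 (1.23 log units; beyond the scatter). On that basis compound 4 is estimated to give 100000 nM in this assay, with a likely range from 35000 nM to 300000 nM.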

Compound 4, concentration lethal to 50% of the cells: 51300 nM
Compound 4: the middle estimate sits 1.9-fold (0.29 log units) above what was measured; the range from low to high includes it.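

In this assay, the exchange of chloro for amino on the aromatic carbon between two ring nitrogen atoms again gave a higher number, an 8.7-fold higher number from compound 2 to compound 4 (0.94 log units; beyond the scatter). Set side by side, the two instances point the same way and do not differ in size by more than the scatter allows: the same change on two cores in this assay, an 18-fold higher number (1.25 log units; beyond the scatter) from compound 1 to compound 3 and an 8.7-fold higher number (0.94 log units; beyond the scatter) from compound 2 to compound 4, 2.0-fold (0.31 log units) apart, within the scatter of two such steps. This shows that the change carried over from the core of compound 1 to the core of compound 2, but a single pair of steps does not establish a general rule for this series, and it does not explain why the number rises.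

Only chloro and amino appear at that carbon in the compounds shown, leaving open how a methylamino or a methoxy group would behave there. Also open, from the compounds shown here alone, is what would happen to this step if the chloromethyl group gave way to a methyl or a hydroxymethyl group.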